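Moving the chlorine on the benzyl arm of compound 3

The source may report more compounds than this note shows. Statements on the series, on what has been measured and on what is new or still open speak of the compounds shown alone.

For the measured compounds named here, compound 3 `Cc1cc(-c2sc(Cc3ccccc3Cl)nc2C)ccc1C(N)=O` is the weakest of the three measured members: in a functional assay on cells for agonist activity at G-protein coupled receptor 52 (Homo sapiens), read by AlphaScreen and cAMP accumulation, with a stated time of 30 min (on this read-out lower numbers stand for an effect already at smaller amounts and higher numbers for an effect only at larger amounts of compound), compound 3 gives 3900 nM, the highest of the three numbers. Compound 1 `COc1cccc(Cc2nc(C)c(-c3ccc(C(N)=O)c(C)c3)s2)c1` gives 160 nM and compound 2 `Cc1cc(-c2sc(Cc3cccc(Cl)c3)nc2C)ccc1C(N)=O` gives 130 nM in this assay; those two stand close together, as the step of a 1.2-fold lower number from compound 1 to compound 2 (0.09 log units; within the scatter) shows. Compound 4 `Cc1cc(-c2sc(Cc3ccc(Cl)cc3)nc2C)ccc1C(N)=O` differs from compound 3 in one place: 4-chlorophenyl in place of 2-chlorophenyl on a saturated chain carbon bound to an aromatic carbon. Going by the values given here, two measured steps bear on this change. a 30-fold higher number from compound 2 to compound 3 (1.48 log units; beyond the scatter) and a 24-fold higher number from compound 1 to compound 3 (1.39 log units; beyond the scatter) both show that a 2-chlorophenyl group on the saturated chain carbon gives a much higher number than a 3-chlorophenyl or a 3-methoxyphenyl group in the same place. Among the compounds with values here, compound 4 carries a 4-chlorophenyl group instead, and no measured compound carries that group, so a return toward the numbers of compound 1 and compound 2 is expected but cannot be assumed to be complete. The step of a 13-fold lower number from compound 3 to compound 4 (1.11 log units; beyond the scatter) is therefore expected to be large and downward. In this assay compound 4 is estimated at 300 nM, with a range from 80 nM to 1200 nM.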

Compound 4, half-maximal effective concentration: 210 nM
Compound 4: middle estimate off by 1.4-fold (0.15 log units), on the high side; the range from low to high includes it.
By their numbers in this assay, from the lowest: compounds 2, 1 and 4 (each within the scatter of the next); then compound 3.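

In this assay, the large step of a 19-fold lower number from compound 3 to compound 4 (1.27 log units; beyond the scatter) shows that the high number of compound 3 goes with the 2-chlorophenyl group in particular and not with a chlorophenyl group on the saturated chain carbon as such, for the two compounds have the same atoms, joined differently. The steps of a 1.6-fold higher number from compound 2 to compound 4 (0.21 log units; within the scatter) and a 1.3-fold higher number from compound 1 to compound 4 (0.12 log units; within the scatter) both lie within the scatter, so 4-chlorophenyl, 3-chlorophenyl and 3-methoxyphenyl are not told apart at this position, and among the four compounds only the 2-chlorophenyl group stands apart. Nothing at hand gives a reason for the separate standing of the 2-chlorophenyl group.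

The compounds shown leave open whether a 2-methoxyphenyl or 2-fluorophenyl group on the same carbon would give a number like that of compound 3 or one like that of compound 4. They also leave open how an unsubstituted phenyl group, a 4-methoxyphenyl group or a longer chain in place of the saturated chain carbon would read here.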